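The source may hold more compounds than are shown below. What is called first, only, known or untested is meant among the compounds shown, and "the series" means these compounds.

Compound 3 `COc1cc(-n2cnc3ccc(-c4ccccc4)cc32)cc(OC)c1OC` carries the plain phenyl on the shared core. In a functional assay on SGC-7901 cells (Homo sapiens) for antiproliferative activity, read by MTT assay, with a stated time of 72 h (on this read-out lower numbers stand for stronger inhibition and higher numbers for weaker inhibition), compound 3 gives 290 nM, the lowest of the three numbers measured. Compound 1 `COc1cc(-n2cnc3ccc(-c4ccc(Cl)cc4)cc32)cc(OC)c1OC` carries 4-chlorophenyl instead, and in this assay compound 1 gives 1270 nM. Compound 2 `COc1ccccc1-c1ccc2ncn(-c3cc(OC)c(OC)c(OC)c3)c2c1` carries 2-methoxyphenyl, and in this assay compound 2 gives 5050 nM. The steps toward compound 3 are a 4.4-fold lower number from compound 1 to compound 3 (0.64 log units; beyond the scatter) and a 17-fold lower number from compound 2 to compound 3 (1.24 log units; beyond the scatter); between the two substituted compounds the step is a 4.0-fold higher number from compound 1 to compound 2 (0.60 log units; beyond the scatter).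

Compound 4 `COc1cc(-n2cnc3ccc(-c4cccc(C)c4)cc32)cc(OC)c1OC` differs from compound 3 by methyl in place of hydrogen on an aromatic carbon, phenyl to 3-methylphenyl. Among the measured compounds shown here, no measured step involves a methyl, and none involves a group meta to a large group. What the series does show is that each substituent placed on the pendant phenyl, chloro or methoxy, gave a higher number than hydrogen, so a small rise in this assay, probably beyond the scatter, is expected rather than a fall, with a wide range. Compound 4 is expected at 600 nM in this assay, between 250 nM and 1500 nM, a step of a 2.1-fold higher number from compound 3 to compound 4 (0.32 log units; beyond the scatter) that is an estimate only.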

Compound 4, half-maximal inhibitory concentration: 1240 nM
Compound 4: the middle estimate sits 2.1-fold (0.32 log units) below what was measured; the range from low to high includes it.
By their numbers in this assay, from the lowest: compound 3; then compounds 4 and 1 (each within the scatter of the next); then compound 2.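

In this assay, a single methyl on the pendant phenyl, meta to a large group, already raises the number (a 4.3-fold higher number from compound 3 to compound 4 (0.63 log units; beyond the scatter)), so even this small addition does not match hydrogen. The 3-methylphenyl of compound 4 cannot be told apart from the 4-chlorophenyl of compound 1 (a 1.0-fold lower number from compound 1 to compound 4 (0.01 log units; within the scatter)), whereas the 2-methoxyphenyl of compound 2 remains clearly separated from compound 4 (a 4.1-fold lower number from compound 2 to compound 4 (0.61 log units; beyond the scatter)). Compounds 1, 2 and 4 all give higher numbers than compound 3, with none of the three going against this, but nothing on hand accounts for the rise.

Open, going by these compounds, is whether methyl gives the same result elsewhere on this ring. Also open, on these data alone, is whether an amine, a carboxylic acid or a longer chain on the pendant phenyl could give a number lower than that of compound 3.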